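Trifluoromethyl for Fluoro on a Dimethoxy Core

The source may hold more compounds than are shown below. What is called first, only, known or untested is meant among the compounds shown, and "the series" means these compounds.

Compound 1 `COc1ccc(C(=O)c2cc(OC)c(OC)c(OC)c2)cc1NC(=O)/C=C/c1ccc(F)cc1`: 300 nM
Compound 2 `COc1ccc(C(=O)c2cc(OC)c(OC)c(OC)c2)cc1NC(=O)/C=C/c1ccc(C(F)(F)F)cc1`: 800 nM
Compound 3 `COc1cc(C(=O)c2cc(OC)c(OC)c(OC)c2)cc(NC(=O)/C=C/c2ccc(F)cc2)c1OC`: 1000 nM

These three compounds were tested in a functional assay on ME-180 cells (Homo sapiens) for cytotoxicity, read by MTT assay, with a stated time of 72 h (on this read-out lower numbers stand for stronger inhibition and higher numbers for weaker inhibition), with the values given above. Compound 4 `COc1cc(C(=O)c2cc(OC)c(OC)c(OC)c2)cc(NC(=O)/C=C/c2ccc(C(F)(F)F)cc2)c1OC` has not yet been measured in this assay. The core of compound 3 differs from the core of compound 1 by methoxy in place of hydrogen on an aromatic carbon, and that change made a 3.3-fold higher number from compound 1 to compound 3 (0.52 log units; beyond the scatter). Compound 4 arises from compound 3 by trifluoromethyl in place of fluoro on an aromatic carbon. The same change was already made once, as trifluoromethyl in place of fluoro on an aromatic carbon, and it gave a 2.7-fold higher number from compound 1 to compound 2 (0.43 log units; beyond the scatter). The place of the change is described in the same words in both cases, so it counts as the same change. For compound 4 the expected step is a 2.7-fold higher number from compound 3 to compound 4 (0.43 log units; beyond the scatter), resting on the earlier step of a 2.7-fold higher number from compound 1 to compound 2 (0.43 log units; beyond the scatter). Compound 4 is therefore expected to give 2700 nM, with a likely range from 1100 nM to 6500 nM.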

Compound 4, half-maximal inhibitory concentration: 3600 nM
For compound 4 the middle estimate is 1.3-fold (0.12 log units) below the measured one; the range from low to high includes it.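

In this assay trifluoromethyl in place of fluoro gave a 3.6-fold higher number from compound 3 to compound 4 (0.56 log units; beyond the scatter) and so repeated its earlier step on the other core: the same change on two cores in this assay, a 2.7-fold higher number (0.43 log units; beyond the scatter) from compound 1 to compound 2 and a 3.6-fold higher number (0.56 log units; beyond the scatter) from compound 3 to compound 4, 1.4-fold (0.13 log units) apart, within the scatter of two such steps. Methoxy in place of hydrogen gave a 4.5-fold higher number from compound 2 to compound 4 (0.65 log units; beyond the scatter) and likewise repeated its earlier step: the same change on two cores in this assay, a 3.3-fold higher number (0.52 log units; beyond the scatter) from compound 1 to compound 3 and a 4.5-fold higher number (0.65 log units; beyond the scatter) from compound 2 to compound 4, 1.4-fold (0.13 log units) apart, within the scatter of two such steps. Across these four compounds each change therefore carried over from one core to the other with little difference in size, but two cores in one assay cannot show why either change raises the number or whether it would do so on a further core.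

As far as these compounds go, it remains open how a nitrile, an amine or a carboxylic acid in place of fluoro would behave. A longer chain in place of the methoxy added to the core is also untested among the compounds shown here.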